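Notes on oxetan-3-yl in place of methyl

The compounds below may be only part of what the source reports. "The series", "measured", "known", "first", "only" and "open" are said of these compounds alone.

Measured so far in a physicochemical assay for solubility, read by chemiluminescence, measured as kinetic solubility; on this read-out higher numbers stand for higher solubility and lower numbers for lower solubility:
- compound 1 `COc1nc(NS(=O)(=O)c2cccc(Cl)c2Cl)c2c(OC)nn(C)c2n1` gives 148000 nM
- compound 2 `CNc1nc(NS(=O)(=O)c2cccc(Cl)c2Cl)c2c(OC)nn(C)c2n1` gives 376000 nM

Going by the values given here, of these two, compound 2 stands highest, at 376000 nM in this assay so far. Next comes compound 3 `COc1nn(C)c2nc(NC3COC3)nc(NS(=O)(=O)c3cccc(Cl)c3Cl)c12`, with this difference: oxetan-3-yl in place of methyl on a nitrogen on an aromatic ring. In words, oxetan-3-yl sits in place of methyl on a nitrogen on an aromatic ring. Among the compounds with values here, the only measured step, a 2.5-fold higher number from compound 1 to compound 2 (0.40 log units; beyond the scatter), is modest and concerns a different change, so it bears only indirectly. No step beyond the scatter is therefore expected in this assay. The estimated step is a 1.3-fold lower number from compound 2 to compound 3 (0.10 log units; within the scatter), in line with that expectation. For compound 3 the expected value is 300000 nM, with an estimated range of 130000 nM to 600000 nM.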

Compound 3, solubility: >= 712000 nM
Compound 3 gave a limit, no number; the forecaster's own chance of this, stated with the estimate: 5%; middle value at least 2.3-fold (0.37 log units) from the limit.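

In this assay compound 3 gives >= 712000 nM, which is a limit of the assay and not a number. Oxetan-3-yl in place of methyl on this nitrogen brings no drop, with an at least 1.8-fold higher number from compound 2 to compound 3 (0.27 log units; that floor lies within the scatter), so the true size of this change stays unresolved. Replacing methoxy on the aromatic carbon with (oxetan-3-yl)amino gives a clearer separation, with an at least 4.8-fold higher number from compound 1 to compound 3 (0.68 log units; beyond the scatter).

As far as these compounds go, how a longer chain, a tertiary amine or a carboxylic acid on this nitrogen would read remains open. So does whether the ring of oxetan-3-yl matters, as opposed to an open-chain ether such as 2-methoxyethyl.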